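Swapping the amine end group on a shared core

This account rests on a few compounds, and the source may have more. Where it says the series, first, only, none or still open, it means among the compounds named here.

Measured in a functional assay on SK-BR-3 cells (Homo sapiens) for antiproliferative activity; on this read-out lower numbers stand for stronger inhibition and higher numbers for weaker inhibition:
- Compound 1 `CC(C)=CCc1cc(C(=O)Nc2cc3ccc(OCCCN4CCCC4)c(C)c3oc2=O)ccc1O`: 720 nM
- Compound 2 `CCN(CC)CCCOc1ccc2cc(NC(=O)c3ccc(O)c(CC=C(C)C)c3)c(=O)oc2c1C`: 4900 nM
- Compound 3 `COC(=O)CNCCCOc1ccc2cc(NC(=O)c3ccc(O)c(CC=C(C)C)c3)c(=O)oc2c1C`: 1060 nM

Compound 3 sits near the low end of these numbers, as two steps show: a 1.5-fold higher number from compound 1 to compound 3 (0.17 log units; within the scatter), and a 4.6-fold lower number from compound 2 to compound 3 (0.66 log units; beyond the scatter).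

The next compound, compound 4 `CC(C)=CCc1cc(C(=O)Nc2cc3ccc(OCCCNc4ccccc4)c(C)c3oc2=O)ccc1O`, keeps the shared core and alters only the end of the chain: phenyl in place of (methoxycarbonyl)methyl on an amine nitrogen.

The measured steps that bear on this change also alter the group at the chain end. They show that this region can matter: a 6.8-fold higher number from compound 1 to compound 2 (0.83 log units; beyond the scatter). They can also leave the number almost unmoved, as the step to compound 3 did. Among the measured compounds shown here, no measured compound carries a phenyl there, so the direction stays open, and the value of compound 3 is the natural starting point.

The expected change is small, a 1.1-fold higher number from compound 3 to compound 4 (0.05 log units; within the scatter), so no step beyond the scatter is expected. For compound 4 the estimate is 1200 nM, with an expected range from 400 nM to 3800 nM.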

Compound 4, half-maximal inhibitory concentration: > 50000 nM
Compound 4 ended at the assay's limit; the forecaster's own chance of this, stated with the estimate: 3%; middle value at least 41-fold (1.61 log units) away from the limit.
By their numbers in this assay, from the lowest: compounds 1 and 3 (each within the scatter of the next); then compound 2. At a limit, above all of these: compound 4.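

In this assay compound 4 gives > 50000 nM, which is a limit of the assay and not a number. Phenyl on this amine nitrogen moves the read-out much further than the earlier changes at the chain end did, with an at least 47-fold higher number from compound 3 to compound 4 (1.67 log units; beyond the scatter), an at least 10-fold higher number from compound 2 to compound 4 (1.00 log units; beyond the scatter) and an at least 69-fold higher number from compound 1 to compound 4 (1.84 log units; beyond the scatter). The pyrrolidin-1-yl, diethylamino and ((methoxycarbonyl)methyl)amino ends all gave measured numbers, so this position tolerates those three groups but not anilino, and the end group can decide whether any measurable activity remains.

Going by these compounds, what stays open is which feature of anilino is responsible. A benzylamino or a cyclohexylamino end would help show whether the loss follows any six-membered ring at this position or only a phenyl sitting directly on the nitrogen.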